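A few compounds are considered here, and "the series" means these few. Any claim that something is new, unique, unknown or untested is made for them only; others in the source may bear on it.

Measured so far in an assay on isolated protein for inhibition of DNA nucleotidylexotransferase (Homo sapiens), read by scintillation counting, with a stated time of 10 min; a higher number here means a weaker inhibitor, a lower number a stronger inhibitor:
- compound 3, `CC(C)CCn1cc(/C=C/C(=O)CC(=O)C(=O)O)c2ccccc21`: 16.3 uM
- compound 1, `CCOC(=O)C(=O)CC(=O)/C=C/c1cn(CCC(C)C)c2ccccc12`: the value is a limit of the assay, > 40 uM
- compound 2, `CCOC(=O)C(=O)CC(=O)/C=C/c1cn(C=C(C)C)c2ccccc12`: the value is a limit of the assay, > 40 uM

Among the compounds with values here, compound 3 holds the only number in this assay; the two other values sit at the limit of > 40 uM in this assay, at which 2 of the 3 values shown sit. Within the data shown here, the one readable step is the ethyl ester to acid change, an at least 2.4-fold lower number from compound 1 to compound 3 (0.38 log units; beyond the scatter), which takes the series from a limit to a number. The other measured pair, compound 1 against compound 2, differs in the group on the aromatic nitrogen, but a step that the two limits leave unreadable from compound 1 to compound 2, so it gives no size and no direction.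

Compound 4, `O=C(/C=C/c1cn(-c2ccc(Cl)cc2)c2ccccc12)CC(=O)C(=O)O`, is the next compound for this assay. It keeps the acid of compound 3 and changes the nitrogen substituent: 4-chlorophenyl in place of isopentyl on an aromatic nitrogen. Among the measured compounds shown here, no measured step bears directly on this change; the only precedent for a change at the aromatic nitrogen is the unreadable step from compound 1 to compound 2. With the acid retained, compound 4 is expected to stay near compound 3, and the expected step is a 1.2-fold lower number from compound 3 to compound 4 (0.07 log units; within the scatter), nothing beyond the scatter in either direction. The estimate for compound 4 is therefore 14 uM, within a broad range of 4 uM to 40 uM.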

Compound 4, concentration for 50% inhibition: 31 uM
Beside the measured number, compound 4's estimate is 2.2-fold (0.35 log units) below it; the measured number falls inside the stated range.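

In this assay, within the data shown here, 4-chlorophenyl in place of isopentyl on the aromatic nitrogen gives a 1.9-fold higher number from compound 3 to compound 4 (0.28 log units; within the scatter) and is the first change at this position that can be sized. The earlier change there, between compound 1 and compound 2, runs from one limit to another and cannot be read, whereas the pair of compound 3 and compound 4 shows that, with the acid kept, an aromatic ring can take the place of the open chain and the assay still returns a number. Compound 4 thus stands with compound 3 among the measured values, apart from the two ethyl esters, compound 1 and compound 2, whose values are limits: the limit of > 40 uM in this assay, at which 2 of the 4 values shown sit.

The compounds shown leave open what the chlorine itself contributes, since a plain phenyl or a 4-methoxyphenyl on the aromatic nitrogen would be needed to separate it from the ring. Also open, going by these compounds, is whether a benzyl group, or a longer chain ending in an amine, would move the value beyond the scatter of what isopentyl and 4-chlorophenyl give.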